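A few compounds are considered here, and "the series" means these few. Any claim that something is new, unique, unknown or untested is made for them only; others in the source may bear on it.

Going by the values given here, in a functional assay on L1210 cells (Mus musculus) for antiproliferative activity, read by MTT assay, with a stated time of 72 h (on this read-out lower numbers stand for stronger inhibition and higher numbers for weaker inhibition), compound 1 `COc1cc(/C(=C/c2ccc(C)cc2)C(C)O)cc(OC)c1OC` gives 33500 nM, the only true number among the measured compounds. Compound 2 `COc1cc(/C(=C/c2ccc([N+](=O)[O-])cc2)C(C)O)cc(OC)c1OC` is reported only as a limit, > 100000 nM. Compound 3 `COc1cc(/C(=C/c2cccc([N+](=O)[O-])c2)C(C)O)cc(OC)c1OC` is likewise reported only as a limit, > 100000 nM. Among the compounds with values here, the measured set thus shows (the limit of > 100000 nM in this assay, at which 2 of the 3 values shown sit), and compound 1 is the sole compound with a number.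

Compound 4 `COc1cc(/C(=C/c2ccc(Cl)c(Cl)c2)C(C)O)cc(OC)c1OC` departs from compound 1 at one place, (3,4-dichlorophenyl in place of 4-methylphenyl on a double-bonded chain carbon bound to a double-bonded chain carbon). In words, 3,4-dichlorophenyl stands in place of 4-methylphenyl on a double-bonded chain carbon bound to a double-bonded chain carbon. Within the data shown here, the one measured step that bears on this change, nitro in place of methyl on an aromatic carbon, is an at least 2.9-fold higher number from compound 1 to compound 2 (0.47 log units; beyond the scatter). Among the measured compounds shown here, it rests on a limit, and no measured step introduces chlorine, so it offers only a loose guide. A step within the scatter is therefore expected, leaning towards a higher number. The estimated step is a 1.2-fold higher number from compound 1 to compound 4 (0.08 log units; within the scatter). For compound 4 the expected value is 40000 nM, with an estimated range of 12000 nM to 100000 nM.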

Compound 4, half-maximal inhibitory concentration: 18500 nM
Compound 4: the middle estimate sits 2.2-fold (0.33 log units) above what was measured; the measured number falls inside the stated range.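

In this assay, the change to 3,4-dichlorophenyl on a double-bonded chain carbon bound to a double-bonded chain carbon gives a 1.8-fold lower number from compound 1 to compound 4 (0.26 log units; within the scatter). Going by these compounds alone, until now, the only step read at this ring was the one to nitro, an at least 2.9-fold higher number from compound 1 to compound 2 (0.47 log units; beyond the scatter), so compound 4 shows that a different replacement of the 4-methylphenyl group can leave the read-out within the scatter of compound 1 and give a true number. Compound 2 and compound 3 still stand as limits of the assay, not as numbers: the limit of > 100000 nM in this assay, at which 2 of the 4 values shown sit.

The compounds shown leave open whether one chlorine alone, as in 4-chlorophenyl, would behave as the two chlorines of compound 4 do. They also leave open what an amine or a carboxylic acid on this ring would give.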